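A few compounds are considered here, and "the series" means these few. Any claim that something is new, unique, unknown or untested is made for them only; others in the source may bear on it.

Working notes on the alkoxy group of the series. In a functional assay on MDCK cells (Canis lupus familiaris) for inhibition (on this read-out lower numbers stand for higher toxicity in this test and higher numbers for lower toxicity in this test), compound 1 (`CCCOc1nc(CC2(c3ccccc3)CO2)cc(=O)n1C`) gives > 330000 nM, which is a limit of the assay and not a number. In this assay compound 2 (`Cn1c(OC2CCCCC2)nc(CC2(c3ccccc3)CO2)cc1=O`) gives > 294000 nM, which is likewise a limit. Compound 2 therefore has no readable value and cannot be ranked, and both values shown in this assay are limits.

The next step leads to compound 3 (`COc1nc(CC2(c3ccccc3)CO2)cc(=O)n1C`), with methyl in place of cyclohexyl on an oxygen on an aromatic ring.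

Among the compounds with values here, only one measured step bears on this change, and it is a step that the two limits leave unreadable from compound 1 to compound 2. It offers no size and no direction to carry over. No step beyond the usual scatter is expected in this assay, since a step that the two limits leave unreadable from compound 1 to compound 2 shows no measurable toxicity to build on. The expected outcome for compound 3 is another limit rather than a number.

The estimated value for compound 3 is 350000 nM, with an expected range from 200000 nM to 450000 nM. This estimate means an expected step that the limit leaves unreadable from compound 2 to compound 3.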

Compound 3, half-maximal cytotoxic concentration: > 360000 nM
Compound 3: a limit, no number (the forecaster's own chance of this, stated with the estimate: 85%); at least 1.0-fold (0.01 log units) between middle value and limit.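

In this assay compound 3 gives > 360000 nM, which is a limit of the assay and not a number. Within the data shown here, compound 1 and compound 2 also stand at limits, so no step among compound 1, compound 2 and compound 3 can be read. The compounds shown leave open whether changing the alkoxy group alters toxicity in this test.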